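The source may hold more compounds than are shown below. What is called first, only, known or untested is meant among the compounds shown, and "the series" means these compounds.

Measured compounds:
compound 1, `COc1ccc(C(=O)/C=C\Nc2ccc(-c3nc4cc(OC)c(OC)c(OC)c4s3)cc2)cc1[N+](=O)[O-]`: 11400 nM
compound 2, `COc1ccc(C(=O)/C=C\Nc2ccc(-c3nc4cc(OC)c(OC)c(OC)c4s3)cc2)cc1F`: 7300 nM
compound 3, `COc1cc(C(=O)/C=C\Nc2ccc(-c3nc4cc(OC)c(OC)c(OC)c4s3)cc2)cc([N+](=O)[O-])c1OC`: 7800 nM

Of the compounds shown here, three have been measured in a functional assay on HeLa cells (Homo sapiens) for antiproliferative activity, read by sulforhodamine B assay, with a stated time of 48 h; a higher number here means a weaker inhibitor, a lower number a stronger inhibitor. Compound 3 gives 7800 nM, compound 1 gives 11400 nM and compound 2 gives 7300 nM; all three numbers fall within the scatter of one another, so no order among them can be read from these data.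

Compound 1 differs from compound 3 by hydrogen in place of methoxy on an aromatic carbon. The step of a 1.5-fold higher number from compound 3 to compound 1 (0.16 log units; within the scatter). The cores of compound 2 and compound 3 differ in a way that is not broken down here; what the two values show is a gap within the scatter.

Compound 4, `COc1cc(OC)c2sc(-c3ccc(N/C=C\C(=O)c4ccc(OC)c(F)c4)cc3)nc2c1`, has not yet been measured. It differs from compound 2 by hydrogen in place of methoxy on an aromatic carbon. This is the same kind of change as that from compound 3 to compound 1, but the place is not the same: in compound 4 the methoxy leaves a ring that is part of a fused or bridged system of two rings, ortho to two methoxy groups, meta to a fused ring and para to a fused ring, whereas in compound 1 it left a ring ortho to a methoxy group, meta to a large group and meta to a nitro group.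

In this assay the step from compound 2 to compound 4 is expected to be a 1.4-fold higher number from compound 2 to compound 4 (0.14 log units; within the scatter), resting on the step of a 1.5-fold higher number from compound 3 to compound 1 (0.16 log units; within the scatter) and on the fact that the two places differ. Compound 4 is accordingly estimated at 10000 nM, with a range from 4000 nM to 25000 nM.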

Compound 4, half-maximal inhibitory concentration: 7300 nM
Compound 4: the middle estimate sits 1.4-fold (0.14 log units) above what was measured; the measured number falls inside the stated range.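

Putting hydrogen in place of methoxy on the six-membered aromatic ring of the fused system gives, in this assay, no change at the digits printed from compound 2 to compound 4 (within the scatter) on the core of compound 2. The change therefore leaves the number within the scatter on both cores shown, so nothing here suggests that it behaves differently from one core to the other, but the two pairs differ in where the methoxy sits as well as in the rest of the molecule, and two small steps cannot show that the change is without effect on other cores or at other places in the series. Set side by side, the two steps compare as follows: the same change on two cores in this assay, a 1.5-fold higher number (0.16 log units; within the scatter) from compound 3 to compound 1 and no change at the digits printed (within the scatter) from compound 2 to compound 4, 1.5-fold (0.16 log units) apart, within the scatter of two such steps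

The compounds shown leave open whether another group at the place on the fused ring that compound 4 leaves bare, such as a hydroxyl, an amine or a longer alkoxy chain, would move the number beyond the scatter. They also leave open whether a carboxylic acid or an amine on the other aromatic ring, in place of the fluoro or nitro group, would do so on either core.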